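Swapping a diamine for a carbamoyl group on the sulfur chain

The source may report more compounds than this note shows. Statements on the series, on what has been measured and on what is new or still open speak of the compounds shown alone.

Compound 1 `CC(C)c1n[nH]c2c(NCc3ccc(-c4ccccn4)cc3)nc(SCC(N)CN)nc12`: 480 nM
Compound 2 `CC(O)CSc1nc(NCc2ccc(-c3ccccn3)cc2)c2[nH]nc(C(C)C)c2n1`: 62 nM
Compound 3 `CC(C)c1n[nH]c2c(NCc3ccc(-c4ccccn4)cc3)nc(SCC(C)(C)O)nc12`: 507 nM

These three compounds share one core and differ only in the group carried on the saturated chain carbon bound to a sulfur. In a functional assay on HT cells (Homo sapiens) for antiproliferative activity, read by fluorescence, with a stated time of 72 h (a lower number here means a stronger inhibitor of growth, a higher number a weaker inhibitor of growth), compound 1 gives 480 nM, the second highest of the three numbers; compound 3 sits within the scatter of it, while compound 2 is clearly stronger.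

Compound 4 `CC(C)c1n[nH]c2c(NCc3ccc(-c4ccccn4)cc3)nc(SCC(N)=O)nc12` is the next member of the set, and it differs from compound 1 as follows: carbamoyl in place of 1,2-diaminoethyl on a saturated chain carbon bound to a sulfur.

Two measured steps from compound 1 bear on this. Replacing the diamine by a small hydroxyl-bearing chain gave a 7.7-fold lower number from compound 1 to compound 2 (0.89 log units; beyond the scatter), whereas a bulkier hydroxyl-bearing chain gave a 1.1-fold higher number from compound 1 to compound 3 (0.02 log units; within the scatter). Removing the diamine can therefore either help modestly or change nothing; the carbamoyl group is a third, untested replacement, so the step is expected to fall somewhere between those two outcomes, most likely a small drop in the number that may not clear the scatter.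

The expected step is a 1.9-fold lower number from compound 1 to compound 4 (0.28 log units; within the scatter). Compound 4 is therefore estimated at 250 nM, with a range of 80 nM to 900 nM.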

Compound 4, concentration for 50% growth inhibition: 192 nM
Compound 4: the middle estimate sits 1.3-fold (0.11 log units) above what was measured; the range from low to high includes it.
By their numbers in this assay, from the lowest: compound 2; then compound 4; then compounds 1 and 3 (each within the scatter of the next).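

In this assay, carbamoyl on a saturated chain carbon bound to a sulfur gives a clear gain over 1,2-diaminoethyl (a 2.5-fold lower number from compound 1 to compound 4 (0.40 log units; beyond the scatter)), so a group without a hydroxyl can also improve on the diamine. The same group also does better than 1-hydroxy-1-methylethyl (a 2.6-fold lower number from compound 3 to compound 4 (0.42 log units; beyond the scatter)) yet falls short of 1-hydroxyethyl (a 3.1-fold higher number from compound 2 to compound 4 (0.49 log units; beyond the scatter)), which shows that replacing the diamine has more than the two outcomes seen earlier: the four compounds now fall into three levels, with compound 2 lowest, compound 4 in the middle, and compounds 1 and 3 together at the top. Nothing available here explains why these groups fall in this order.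

The compounds shown leave open whether the gain with carbamoyl follows the carbonyl or the amide nitrogen, a question that a carboxylic acid or a methyl ester at the same place could help to settle. They also leave open how far the result depends on chain length, which a longer chain such as carbamoylethyl or a single primary amine on the chain could test.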